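Carbonyl substituents on the ring nitrogen of a shared core

The compounds below may be only part of what the source reports. "The series", "measured", "known", "first", "only" and "open" are said of these compounds alone.

Measured compounds in a functional assay on isolated protein for inhibition of Glucose-dependent insulinotropic receptor (Rattus norvegicus), read by HTRF and cAMP accumulation; on this read-out higher numbers stand for an effect only at larger amounts of compound and lower numbers for an effect already at smaller amounts:
Compound 1, `Cc1nc(S(C)(=O)=O)ccc1Oc1ncnc(OC2CCN(C(=O)OC(C)(C)C(F)(F)F)CC2)c1F`: 47.2 nM
Compound 2, `Cc1nc(S(C)(=O)=O)ccc1Oc1ncnc(OC2CCN(C(=S)OC(C)C)CC2)c1F`: 1050 nM
Compound 3, `Cc1nc(S(C)(=O)=O)ccc1Oc1ncnc(OC2CCN(C(=O)C(C)(F)F)CC2)c1F`: 239 nM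

All three share one core and differ only in the group carried by the amine nitrogen in a ring. Compound 3 stands second highest of the three numbers: against compound 2 the step is a 4.4-fold lower number from compound 2 to compound 3 (0.64 log units; beyond the scatter), and against compound 1 it is a 5.1-fold higher number from compound 1 to compound 3 (0.70 log units; beyond the scatter). The widest gap in the set is a 22-fold higher number from compound 1 to compound 2 (1.35 log units; beyond the scatter).

Compound 4, `Cc1nc(S(C)(=O)=O)ccc1Oc1ncnc(OC2CCN(C(=O)c3ncc(Cl)cn3)CC2)c1F`, keeps everything but the group on the carbonyl carbon.
5-chloropyrimidin-2-yl in place of 1,1-difluoroethyl on a carbonyl carbon

All three measured steps bear on this position, since each exchanges the group on the same nitrogen, yet none of them introduces a six-membered aromatic ring with 2 hetero atoms; the steps show that this position tolerates large changes in the number, in both directions. Compound 4 is therefore expected to lie somewhere within the spread of compounds 1 to 3 in this assay, with no firm direction beyond the scatter. Compound 4 is estimated at 150 nM, in the range 40 nM to 600 nM, a step of a 1.6-fold lower number from compound 3 to compound 4 (0.20 log units; within the scatter) that is expected rather than known.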

Compound 4, half-maximal effective concentration: 30.9 nM
Beside the measured number, compound 4's estimate is 4.9-fold (0.69 log units) above it, outside the stated range (below it).
By their numbers in this assay, from the lowest: compounds 4 and 1 (each within the scatter of the next); then compound 3; then compound 2.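

In this assay, within the data shown here, a six-membered aromatic ring with 2 hetero atoms on the carbonyl carbon reaches the low end of the series: 5-chloropyrimidin-2-yl in place of 1,1-difluoroethyl gives a 7.7-fold lower number from compound 3 to compound 4 (0.89 log units; beyond the scatter) as the step, and the exchange of the whole group on the ring nitrogen gives a 34-fold lower number from compound 2 to compound 4 (1.53 log units; beyond the scatter) as the largest step so far. Against the earlier low point, the reading is a 1.5-fold lower number from compound 1 to compound 4 (0.18 log units; within the scatter) and so two very different groups, 5-chloropyrimidin-2-yl and 1-methyl-1-(trifluoromethyl)ethoxy, cannot be told apart on this read-out, which shows that this position does not depend on the acyclic fluorinated group of compound 1 for a low number. No measurement at hand says what lies behind these steps.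

As far as these compounds go, whether the chlorine contributes stays open, and a plain pyrimidin-2-yl or a 5-methoxypyrimidin-2-yl on the same carbonyl carbon would address that. Also open, from the compounds shown here alone, is how much of the high number of compound 2 belongs to its sulfur, a question that an isopropoxy group on a carbonyl carbon, with oxygen in place of that sulfur, would settle.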